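From a difluorophenyl group to a hydroxyphenyl group

The source may report more compounds than this note shows. Statements on the series, on what has been measured and on what is new or still open speak of the compounds shown alone.

Of the compounds shown here, two with the same core have been tested in a functional assay on OVCAR-8 cells (Homo sapiens); on this read-out higher numbers stand for weaker inhibition of growth and lower numbers for stronger inhibition of growth. Compound 1 `O=S(=O)(/C=C/c1ccc(Cl)cc1Cl)Cc1ccc(Nc2ncnc3ccccc23)cc1`, which carries 2,4-dichlorophenyl, gives 4000 nM. Compound 2 `O=S(=O)(/C=C/c1ccc(F)cc1F)Cc1ccc(Nc2ncnc3ccccc23)cc1`, which carries 2,4-difluorophenyl, gives > 100000 nM, and this is a limit of the assay, not a number.

Going by the values given here, the only measured step, an at least 25-fold higher number from compound 1 to compound 2 (1.39 log units; beyond the scatter), is large and beyond the scatter, so the group at this place can matter a great deal. Compound 3 `O=S(=O)(/C=C/c1ccc(O)cc1)Cc1ccc(Nc2ncnc3ccccc23)cc1` changes the same place again: 4-hydroxyphenyl in place of 2,4-difluorophenyl on a double-bonded chain carbon bound to a double-bonded chain carbon. Among the compounds with values here, no measured step involves 4-hydroxyphenyl, so the size of this change remains uncertain.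

Compound 1, at 4000 nM, shows that a measurable number can be reached with this core. A move towards a lower number is therefore expected for compound 3, although it may also remain at the limit of this assay. The estimate means an expected at least 3.3-fold lower number from compound 2 to compound 3 (0.52 log units; beyond the scatter). For compound 3, the estimated value is 30000 nM, with an expected range from 4000 nM to 100000 nM.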

Compound 3, concentration for 50% growth inhibition: 1000 nM
Estimate against measurement, compound 3: 30-fold (1.48 log units) above; the measured number lies below the stated range.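

Placing 4-hydroxyphenyl at this position gives an at least 100-fold lower number from compound 2 to compound 3 (2.00 log units; beyond the scatter) in this assay, so a group on this chain can turn a compound with no measurable number into one with a clear value. That step gives only a minimum size, because compound 2 sits at a limit of the assay and has no exact number: the limit of > 100000 nM in this assay, at which 1 of the 3 values shown sits. The comparison with the dichlorophenyl compound can be read more exactly: a 4.0-fold lower number from compound 1 to compound 3 (0.60 log units; beyond the scatter) is a modest gain, and it shows that the best number among these three compounds comes from the ring with neither chlorine nor fluorine, which the first two compounds could not reveal.

Compound 3 both loses the halogens and gains a hydroxyl group, so these compounds cannot tell which of the two changes lies behind its lower number. Results for a plain phenyl, a methoxyphenyl or an aminophenyl group at this place would help to separate those two readings, and would show whether the hydroxyl hydrogen itself matters.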